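The compounds below may be only part of what the source reports. "The series", "measured", "known", "first", "only" and "open" are said of these compounds alone.

Measured so far in an ADME assay on CCRF-HSB-2 cells (Homo sapiens) for cytotoxicity, with a stated time of 7 days; on this read-out higher numbers stand for lower toxicity in this test and lower numbers for higher toxicity in this test:
- compound 1 `C=CCOc1nc(N)nc2c1ncn2/C=C1/CC1(CO)CO`: > 20000 nM
- compound 2 `CCCCCCCCOc1nc(N)nc2c1ncn2/C=C1/CC1(CO)CO`: > 20000 nM
- compound 3 `CSc1nc(N)nc2c1ncn2/C=C1/CC1(CO)CO`: > 100000 nM

All three entries are limits of the assay, not numbers. Compound 3 stands only at a limit, > 100000 nM, which is the highest of the limits shown: the limit of > 100000 nM in this assay, at which 1 of the 3 values shown sits. The other two entries share a different limit: the limit of > 20000 nM in this assay, at which 2 of the 3 values shown sit.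

Compound 4 `Nc1nc(SC2CCCC2)c2ncn(/C=C3/CC3(CO)CO)c2n1` follows from compound 3 by cyclopentyl in place of methyl on a sulfur. The measured steps closest to this change alter the group on the same aromatic carbon: a step that the two limits leave unreadable from compound 1 to compound 3 and a step that the two limits leave unreadable from compound 2 to compound 3. The chain change gives the same picture: a step that the two limits leave unreadable from compound 1 to compound 2. None of these has a size that can be carried over, so no direction can be taken from them, and no step beyond the scatter is expected in this assay. The expected result is an at least 1.6-fold lower number from compound 3 to compound 4 (0.22 log units; that floor lies within the scatter). A report as a limit alone is the likeliest outcome. For compound 4 the estimate is 60000 nM, with an expected range of 20000 nM to 150000 nM.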

Compound 4, half-maximal cytotoxic concentration: 91000 nM
The estimate for compound 4 lay 1.5-fold (0.18 log units) below the measured number; the range from low to high includes it.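

In this assay compound 4 gives 91000 nM, the only entry in this set that is a number rather than a limit, so this aromatic carbon now has one measured reference point, for cyclopentylsulfanyl. Cyclopentyl in place of methyl on a sulfur gives an at least 1.0-fold lower number from compound 3 to compound 4 (0.04 log units; that floor lies within the scatter), and only that floor can be read, so the true size of the step remains unknown. Compound 3 still stands at a limit of the assay: the limit of > 100000 nM in this assay, at which 1 of the 4 values shown sits.

The steps from compound 1 and from compound 2 to compound 4 cannot be read, which leaves open how allyloxy and octyloxy compare with cyclopentylsulfanyl. Also open, going by these compounds, is whether phenyl or a longer chain on the sulfur would give a step beyond the scatter.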